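A larger aromatic group replaces cyclopropyl in compound 4

This account rests on a few compounds, and the source may have more. Where it says the series, first, only, none or still open, it means among the compounds named here.

Three compounds share one core and differ only in the group on an aromatic carbon. Compound 1 `Cc1cc(NC(=O)Cn2nnc(-c3cccnc3)n2)n(C2CCCCC2)n1` gives 1930 nM in an assay on HEK293 cells for activation of Kir3.1/Kir3.2 (Homo sapiens), read by thallium flux; on this read-out lower numbers stand for an effect already at smaller amounts and higher numbers for an effect only at larger amounts of compound. Compound 2 `Cc1cc(NC(=O)Cn2nnc(-c3cccc(F)n3)n2)n(C2CCCCC2)n1` reaches only the limit > 3000 nM in this assay. Compound 3 `Cc1cc(NC(=O)Cn2nnc(C3CC3)n2)n(C2CCCCC2)n1` likewise reaches only the limit > 3000 nM in this assay. Compound 3 therefore stands at the limit of > 3000 nM in this assay, at which 2 of the 3 values shown sit. The measured steps are an at least 1.5-fold higher number from compound 1 to compound 2 (0.19 log units; that floor lies within the scatter) and an at least 1.5-fold higher number from compound 1 to compound 3 (0.19 log units; that floor lies within the scatter), while a step that the two limits leave unreadable from compound 2 to compound 3.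

Compound 4 `Cc1cc(NC(=O)Cn2nnc(-c3ccc(C(F)(F)F)cc3)n2)n(C2CCCCC2)n1` differs from compound 3 by 4-(trifluoromethyl)phenyl in place of cyclopropyl on an aromatic carbon. Among the compounds with values here, the step that bears on it most directly is the one from compound 1 to compound 3, where an aromatic ring gave way to cyclopropyl and the number rose to the limit; the change to compound 4 brings an aromatic ring back, so a lower number is expected, yet compound 2 shows that not every aromatic ring yields a readable value. Compound 4 is therefore expected to give about 2000 nM in this assay, within 600 nM to 6000 nM, an expected step of an at least 1.5-fold lower number from compound 3 to compound 4 (0.17 log units; that floor lies within the scatter).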

Compound 4, half-maximal effective concentration: 241 nM
Compound 4: middle estimate off by 8.3-fold (0.92 log units), on the high side; the measured number lies below the stated range.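

In this assay, within the data shown here, this position now proves able to move the read-out beyond the scatter, which no earlier step showed: the exchange of cyclopropyl for 4-(trifluoromethyl)phenyl gives an at least 12-fold lower number from compound 3 to compound 4 (1.09 log units; beyond the scatter) and the exchange of 6-fluoropyridin-2-yl for the same group gives an at least 12-fold lower number from compound 2 to compound 4 (1.09 log units; beyond the scatter). Having an aromatic ring here does not by itself settle the outcome, since the exchange of pyridin-3-yl, also an aromatic ring, for 4-(trifluoromethyl)phenyl still gives an 8.0-fold lower number from compound 1 to compound 4 (0.90 log units; beyond the scatter). Compound 2 and compound 3 remain limits and not numbers: the limit of > 3000 nM in this assay, at which 2 of the 4 values shown sit.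

The compounds shown leave open whether the carbon-only aromatic ring or the trifluoromethyl group carries these steps. They also leave open how a plain phenyl, or a phenyl bearing a methoxy group or a nitrile in place of trifluoromethyl, would read.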